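Swapping the ring fluorine for chlorine

This account rests on a few compounds, and the source may have more. Where it says the series, first, only, none or still open, it means among the compounds named here.

Compound 2 `O=C(Nc1ccc(Oc2ccncc2-c2cccnc2)c(F)c1)c1nn(-c2ccc(F)cc2)c(=O)c2ccccc12` gives 990 nM in a functional assay on HT-29 cells (Homo sapiens) for cytotoxicity, read by MTT assay, with a stated time of 72 h; a higher number here means a weaker inhibitor, a lower number a stronger inhibitor. Its number is the lower of the two measured, yet the gap to compound 1 `O=C(Nc1ccc(Oc2ccncc2-c2cccnc2)c(F)c1)c1nn(-c2ccccc2)c(=O)c2ccccc12`, which in this assay gives 1240 nM, lies within the scatter, so the two cannot be told apart. Compound 3 `O=C(Nc1ccc(Oc2ccncc2-c2cccnc2)c(F)c1)c1nn(-c2ccc(Cl)cc2)c(=O)c2ccccc12` differs from compound 2 by chloro in place of fluoro on an aromatic carbon. Within the data shown here, the only measured step bearing on this, a 1.3-fold lower number from compound 1 to compound 2 (0.10 log units; within the scatter), also altered the ring of carbon only and stayed within the scatter, so little movement is expected here. Compound 3 is therefore estimated at 850 nM, in a range from 300 nM to 2500 nM. The expected step, a 1.2-fold lower number from compound 2 to compound 3 (0.07 log units; within the scatter), stays within the scatter.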

Compound 3, half-maximal inhibitory concentration: 710 nM
The estimate for compound 3 lay 1.2-fold (0.08 log units) above the measured number; low and high end bracket the measured number.
By their numbers in this assay, from the lowest: compounds 3, 2 and 1 (each within the scatter of the next).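

In this assay, going from 4-fluorophenyl to 4-chlorophenyl gives a 1.4-fold lower number from compound 2 to compound 3 (0.14 log units; within the scatter), and chloro in place of hydrogen gives a 1.7-fold lower number from compound 1 to compound 3 (0.24 log units; within the scatter). This position has now carried hydrogen, fluoro and chloro with no step beyond the scatter, so these three small substituents cannot be told apart here. No measurement available here offers an explanation for this result. On these data alone, whether an amine, a carboxylic acid or a methoxy group at this position would give a step beyond the scatter remains open, as does the effect of changes elsewhere on the shared core.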